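Adding a bromo group to the weakest compound so far

The source may hold more compounds than are shown below. What is called first, only, known or untested is meant among the compounds shown, and "the series" means these compounds.

Measured compounds:
- compound 1, `CC(=O)c1ccc(OCc2cccc(Br)c2)cc1O`, 15800 nM
- compound 2, `O=c1ccoc2cccc(OCc3ccccc3)c12`, 143000 nM

Both compounds were tested in an assay on isolated protein for inhibition of Amine oxidase [flavin-containing] A (Homo sapiens), read by fluorescence, with a stated time of 20 min; a higher number here means a weaker inhibitor, a lower number a stronger inhibitor. Compound 2 has the highest number of the two: nearest to it stands compound 1, with a clearly lower number, a gap beyond the usual scatter. The two compounds share no single-point change, since compound 1 is built on a different core, so their values are simply shown side by side.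

Compound 3, `O=c1ccoc2cccc(OCc3ccc(Br)cc3)c12`, keeps the core of compound 2 and differs from it in one place: bromo in place of hydrogen on an aromatic carbon. Among the measured compounds shown here, no measured pair shows this exact change, so the size of the step is open. Adding one bromine to a benzylic ring has, in many series, shifted numbers modestly, and here a small gain in potency is expected, so the step from compound 2 to compound 3 is estimated as a 2.4-fold lower number from compound 2 to compound 3 (0.38 log units; beyond the scatter). For compound 3 in this assay the expected value is 60000 nM, with a range from 20000 nM to 180000 nM.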

Compound 3, half-maximal inhibitory concentration: 52900 nM
The estimate for compound 3 lay 1.1-fold (0.05 log units) above the measured number; the measured number falls inside the stated range.
By their numbers in this assay, from the lowest: compound 1; then compound 3; then compound 2.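

This is the first single-point change among these compounds, so a step in this assay can now be read directly: bromo in place of hydrogen on an aromatic carbon, para to a large group, gives a 2.7-fold lower number from compound 2 to compound 3 (0.43 log units; beyond the scatter) on the shared core. The step is modest but beyond the scatter, so this position accepts one added heavy atom, and the number moves towards a stronger inhibitor. Nothing measured here accounts for the shift.

From the compounds shown here alone, it remains open whether this gain is particular to bromine or would also appear with another group at the same place, such as a chloro group, a methoxy group or an amine. The effect of moving the bromo group to another carbon of that ring is also unknown.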